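This account rests on a few compounds, and the source may have more. Where it says the series, first, only, none or still open, it means among the compounds named here.

The series rests on a cinnamate ester linked through an oxyacetyl amide, with the amide nitrogen varied. Compound 1 `COc1ccc(/C=C/C(=O)OCC(=O)Nc2ccccc2)cc1OC` carries the amide nitrogen on a phenyl group; in a functional assay on HL-60 cells (Homo sapiens) for cytotoxicity, read by MTT assay, with a stated time of 72 h (on this read-out higher numbers stand for weaker inhibition and lower numbers for stronger inhibition), compound 1 gives 46400 nM. Compound 2 `COCOc1cc(/C=C/C(=O)OCC(=O)NCc2ccco2)ccc1OCc1ccccc1` carries a (furan-2-yl)methyl group on the same nitrogen, and in this assay compound 2 gives 82200 nM, which sits within the scatter of compound 1, so no order between the two can be read. Compound 3 `CCOc1ccc(COc2c(OC)cc(/C=C/C(=O)OCC(=O)Nc3ccccc3)cc2OC)cc1` reaches only the limit of this assay, > 200000 nM, and gives no number; this is the limit recorded as the limit of > 200000 nM in this assay, at which 1 of the 3 values shown sits.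

Compound 4 `COCOc1cc(/C=C/C(=O)OCC(=O)Nc2ccc(Cl)cc2)ccc1OCc1ccccc1` is compound 2 with one change: 4-chlorophenyl in place of (furan-2-yl)methyl on an amide-type nitrogen. Since compound 1, also an anilide on the shared core, gives 46400 nM, the step from compound 2 to compound 4 is expected to stay within the scatter, perhaps leaning toward a lower number, as a 1.4-fold lower number from compound 2 to compound 4 (0.14 log units; within the scatter). For compound 4 in this assay the estimate is 60000 nM, expected to fall between 20000 nM and 200000 nM.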

Compound 4, half-maximal inhibitory concentration: > 200000 nM
Compound 4 gave a limit, no number; the forecaster's own chance of this, stated with the estimate: 25%; middle value at least 3.3-fold (0.52 log units) away from the limit.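

On the amide-type nitrogen of the shared core, 4-chlorophenyl in place of (furan-2-yl)methyl gives an at least 2.4-fold higher number from compound 2 to compound 4 (0.38 log units; beyond the scatter) in this assay, the only readable step shown so far and one that lies beyond the scatter. Among the compounds shown here, the earlier compounds offered no comparison differing in one place, so this is the first sign that the group on this nitrogen alone can shift the read-out on this core. Compound 4 gives a limit and not a number, which leaves the size of the step without an upper end: the limit of > 200000 nM in this assay, at which 2 of the 4 values shown sit.

The compounds shown do not separate the effect of the chlorine from that of the phenyl ring, or the furan ring from its methyl link to the nitrogen. Going by these compounds, how a dimethylaminoethyl group or a carboxylic acid-bearing chain on the same nitrogen would read in this assay also remains open.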